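This account rests on a few compounds, and the source may have more. Where it says the series, first, only, none or still open, it means among the compounds named here.

Measured in this series:
compound 1 `COC(=O)C1=C(C)NC(=S)NC1c1cccs1`: 1%
compound 2 `CCCOC(=O)C1=C(C)NC(=S)NC1c1cccs1`: 10%
compound 3 `COC(=O)C1=C(C)N(C)C(=O)NC1c1ccoc1`: 7%

In an assay on membranes from HeLa cells for displacement of a labelled ligand from adenosine receptor A3 (Homo sapiens), read by scintillation counting, with a stated time of 180 min, tested at 1 uM (on this read-out lower numbers stand for less inhibition and higher numbers for more inhibition at the one concentration tested (going by the name of the read-out)), compound 1 gives 1% and compound 2 gives 10%. The step between them, a number 9 percentage points higher from compound 1 to compound 2 (within the scatter), follows the change (ethyl in place of hydrogen on a saturated chain carbon bound to an oxygen next to a carbonyl group). Compound 3 gives 7% in this assay; the difference between the core of compound 3 and the core of compound 1 is not broken down here, and the values of compound 3 and compound 2 lie close together.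

Compound 4 `CCCOC(=O)C1=C(C)N(C)C(=O)NC1c1ccoc1` is compound 3 carrying the change (ethyl in place of hydrogen on a saturated chain carbon bound to an oxygen next to a carbonyl group), the same change as that from compound 1 to compound 2, at the same place. Because a number 9 percentage points higher from compound 1 to compound 2 (within the scatter) stayed within the scatter, a step of similar size is expected for compound 4, namely a number 6 percentage points higher from compound 3 to compound 4 (within the scatter) in this assay. Compound 4 is therefore estimated at 13%, with the expected range running from 0% to 30%.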

Compound 4, a percentage reported as inhibition, at one concentration (the size of the read-out at that concentration, not a potency): 16%
Estimate against measurement, compound 4: 3 percentage points below, and the stated range covers the measured number.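

The change from methoxycarbonyl to propoxycarbonyl gives a number 9 percentage points higher from compound 3 to compound 4 (within the scatter) in this assay, and it matches the step on the other core: the same change on two cores in this assay, a number 9 percentage points higher (within the scatter) from compound 1 to compound 2 and a number 9 percentage points higher (within the scatter) from compound 3 to compound 4, 0 percentage points apart, within the scatter of two such steps. The change therefore reads alike on the two cores shown, which differ from each other in more than one place. Each step lies within the scatter, however, so this agreement does not show that the change has a real effect on either core, and it says nothing about any third core or about potency, since the read-out comes from one concentration.

The compounds shown leave open how a longer chain, such as butyl, would read at this place. They also leave open whether a carboxylic acid or an amine there would read differently.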